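The source may report more compounds than this note shows. Statements on the series, on what has been measured and on what is new or still open speak of the compounds shown alone.

Series notes. Compound 1, `CNc1nc(NCc2ccc(NC(=O)c3ccc(F)cc3)cc2Cl)c2ccccc2n1`, and compound 2, `CCNc1nc(NCc2ccc(NC(=O)c3ccc(F)cc3)cc2Cl)c2ccccc2n1`, share one core; compound 3, `CCCNc1nc(NCc2ccc(C(=O)Nc3ccc(F)cc3)cc2)c2ccccc2n1`, and compound 4, `CCCCNc1nc(NCc2ccc(C(=O)Nc3ccc(F)cc3)cc2)c2ccccc2n1`, share another. The difference between the two cores is not broken down here.

In a functional assay on SW480 cells (Homo sapiens) for inhibition, read by luminescence and resazurin assay, with a stated time of 3 days (on this read-out higher numbers stand for weaker inhibition and lower numbers for stronger inhibition), compound 1 gives 2300 nM. In this assay compound 2 gives 1600 nM. The change between them is methyl in place of hydrogen on a saturated chain carbon bound to a nitrogen on an aromatic ring, and it produced a 1.4-fold lower number from compound 1 to compound 2 (0.16 log units; within the scatter). In this assay compound 3 gives 1600 nM, the same digits as compound 2, so the two values show no separation.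

Compound 4 is not yet measured. It differs from compound 3 by methyl in place of hydrogen on a saturated chain carbon, three bonds along the chain from a nitrogen on an aromatic ring. Within the data shown here, this is the same kind of change as the one from compound 1 to compound 2, but not the same: there the new methyl sits on a saturated chain carbon bound to a nitrogen on an aromatic ring, here on a saturated chain carbon three bonds along the chain from a nitrogen on an aromatic ring, so the chain is one carbon longer at the start and grows at its far end.

Among the measured compounds shown here, the only measured example of this kind of change is a 1.4-fold lower number from compound 1 to compound 2 (0.16 log units; within the scatter), which lay within the scatter. On that basis a step of about the same size is expected, a 1.2-fold lower number from compound 3 to compound 4 (0.09 log units; within the scatter), with no reason in the data to expect more. For compound 4 the estimate in this assay is 1300 nM, with a plausible span from 600 nM to 3000 nM.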

Compound 4, half-maximal inhibitory concentration: 1000 nM
For compound 4 the middle estimate is 1.3-fold (0.11 log units) above the measured one; low and high end bracket the measured number.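

In this assay, the methyl added at the far end of the chain, taking propyl to butyl, gives a 1.6-fold lower number from compound 3 to compound 4 (0.20 log units; within the scatter), a step that cannot be told apart from repeat measurement. Set beside the step from methyl to ethyl on the other core, the two agree: the same change on two cores in this assay, a 1.4-fold lower number (0.16 log units; within the scatter) from compound 1 to compound 2 and a 1.6-fold lower number (0.20 log units; within the scatter) from compound 3 to compound 4, 1.1-fold (0.05 log units) apart, within the scatter of two such steps

So on these two pairs the change carries from one core to the other without a step beyond the scatter on either core and without a gap between the cores, but this does not show that lengthening the chain strengthens inhibition on either core, nor that the two cores respond alike in general, since each core offers a single step and the methyl enters at a different place on the chain in each.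

Going by these compounds, whether a longer chain than butyl, or a chain ending in an amine or a carboxylic acid, would move the number beyond the scatter remains open. Also open, on these data alone, is how a propyl or butyl chain behaves on the core of compound 1 and an ethyl chain on the core of compound 3, as no single chain appears here on both cores.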